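Moving the chloro from one ring position to another

This account rests on a few compounds, and the source may have more. Where it says the series, first, only, none or still open, it means among the compounds named here.

The shared core of compound 1 `O=C(NO)c1ccc(NCc2nc(-c3ccccc3)nn2-c2cccc(Cl)c2)cc1` carries a hydroxamic acid on one end and a substituted phenyl ring on a ring nitrogen of the five-membered ring at the other. In an assay on Sf9 cells for inhibition of protein deacetylase HDAC6 (Homo sapiens), read by fluorescence, with a stated time of 40 min, tested at 100 nM (on this read-out lower numbers stand for less inhibition and higher numbers for more inhibition at the one concentration tested (going by the name of the read-out)), compound 1 gives 62.3%. Compound 2 `Cc1cccc(-n2nc(-c3ccccc3)nc2CNc2ccc(C(=O)NO)cc2)c1` replaces the chloro on that phenyl ring with a methyl; in this assay compound 2 gives 66%. Going by the values given here, the one measured step, a number 3.7 percentage points higher from compound 1 to compound 2 (within the scatter), is within the scatter, so these two numbers cannot be told apart. Compound 2 stands highest of the two numbers measured, but only by a margin that repeated measurements could erase.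

Compound 3 `O=C(NO)c1ccc(NCc2nc(-c3ccccc3)nn2-c2ccc(Cl)cc2)cc1` differs from compound 2 in one place: 4-chlorophenyl in place of 3-methylphenyl on an aromatic nitrogen. Among the compounds with values here, this change both brings the chloro back and moves it to a different ring position, and no measured step covers such a move. Within the data shown here, the only step that bears on it, a number 3.7 percentage points higher from compound 1 to compound 2 (within the scatter), shows that swapping chloro for methyl changed little, so a step of roughly that size or none beyond the scatter is expected, as a number 4 percentage points lower from compound 2 to compound 3 (within the scatter). For compound 3 in this assay a value of about 62% is therefore estimated, between 45% and 78%.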

Compound 3, a percentage reported as inhibition, at one concentration (the size of the read-out at that concentration, not a potency): 55.4%
Compound 3: the middle estimate sits 6.6 percentage points above what was measured, within the range that was stated.
By their numbers in this assay, from the lowest: compounds 3, 1 and 2 (each within the scatter of the next, the first and the last beyond it).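

In this assay, the substituted phenyl ring on the aromatic nitrogen now gives its first step beyond the scatter: there is a number 10.6 percentage points lower from compound 2 to compound 3 (beyond the scatter) when 4-chlorophenyl takes the place of 3-methylphenyl. The closer comparison keeps the chloro and alters only its ring position, and with a number 6.9 percentage points lower from compound 1 to compound 3 (within the scatter) lying within the scatter, 4-chlorophenyl and 3-chlorophenyl cannot be told apart here, so the modest step from compound 2 cannot be pinned on the position of the chloro alone. The data at hand offer no measurement that could explain either step.

The compounds shown leave open whether the pattern would hold for 4-methylphenyl, which would separate the choice of group from its ring position within a single pair. They also leave open how the read-out would respond to a quite different group on this phenyl ring, such as an amine or a carboxylic acid, or to a longer chain attached to the aromatic nitrogen in place of the ring.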